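The source may report more compounds than this note shows. Statements on the series, on what has been measured and on what is new or still open speak of the compounds shown alone.

Compounds measured in an assay on isolated protein for displacement of a labelled ligand from secreted frizzled-related protein 1 (Homo sapiens), read by fluorescence polarization, with a stated time of 30 min (a higher number here means a weaker inhibitor, a lower number a stronger inhibitor), so far:

- compound 1 `O=C(c1cccc(Cl)c1)N1CCC(NS(=O)(=O)c2cc(S(=O)(=O)c3ccccc3)ccc2C(F)(F)F)CC1`: 300 nM
- compound 2 `O=S(=O)(NC1CCN(S(=O)(=O)c2ccccc2)CC1)c1cc(S(=O)(=O)c2ccccc2)ccc1C(F)(F)F`: 130 nM
- compound 3 `O=C(O)c1ccc(N2CCC(NS(=O)(=O)c3cc(S(=O)(=O)c4ccccc4)ccc3C(F)(F)F)CC2)cc1`: 120 nM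

Compound 3 has the lowest number of the three, but its gap to compound 2 lies within the scatter; only compound 1 sits clearly apart.

Compound 4 `O=C(O)CCCC(=O)N1CCC(NS(=O)(=O)c2cc(S(=O)(=O)c3ccccc3)ccc2C(F)(F)F)CC1` alters the group on the ring nitrogen: (3-carboxypropyl)carbonyl in place of 4-carboxyphenyl on an amine nitrogen in a ring. Within the data shown here, of the measured steps, the closest comparison is the one that also swaps an acyl for an acid-bearing aryl, a 2.5-fold lower number from compound 1 to compound 3 (0.40 log units; beyond the scatter); the exchange within the acid-bearing and sulfonyl groups, a 1.1-fold lower number from compound 2 to compound 3 (0.03 log units; within the scatter), changed little. Compound 4 returns to an acyl on this nitrogen while keeping an acid, so a modest move back toward compound 1 is expected, a 1.7-fold higher number from compound 3 to compound 4 (0.22 log units; within the scatter). The estimate for compound 4 in this assay is 200 nM, range 80 nM to 500 nM.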

Compound 4, half-maximal inhibitory concentration in the secreted frizzled-related protein 1 assay: 500 nM
Compound 4: middle estimate off by 2.5-fold (0.40 log units), on the low side; the measured number falls inside the stated range.
By their numbers in the secreted frizzled-related protein 1 assay, from the lowest: compounds 3 and 2 (each within the scatter of the next); then compounds 1 and 4 (each within the scatter of the next).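

In the secreted frizzled-related protein 1 assay, the group on the ring nitrogen separates two acid-bearing substituents: (3-carboxypropyl)carbonyl in place of 4-carboxyphenyl gives a 4.2-fold higher number from compound 3 to compound 4 (0.62 log units; beyond the scatter), so a carboxylic acid alone does not keep the number low, with compound 3 at 120 nM and compound 4 at 500 nM. The same group in place of phenylsulfonyl gives a 3.8-fold higher number from compound 2 to compound 4 (0.59 log units; beyond the scatter), whereas 3-carboxypropyl in place of 3-chlorophenyl on the carbonyl carbon gives a 1.7-fold higher number from compound 1 to compound 4 (0.22 log units; within the scatter). In a physicochemical assay for solubility (on this read-out higher numbers stand for higher solubility and lower numbers for lower solubility), compound 3 gives 25000 nM and compound 4 gives 50000 nM, two values within the scatter of each other. No evidence is available to explain these steps.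

Going by these compounds, whether the gap follows the carbonyl or the loss of the aromatic ring remains open, and a 4-carboxybenzoyl group on this nitrogen would separate the two. On these data alone, the effect of an amine in place of the acid also remains open.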